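This account rests on a few compounds, and the source may have more. Where it says the series, first, only, none or still open, it means among the compounds named here.

In an ADME assay (liver) for metabolic stability, with Liver microsome (Homo sapiens) as the target, read by LC-MS, using microsomes and NADPH, with a stated time of 5 min, at 37 degrees C (on this read-out higher numbers stand for fast clearance and lower numbers for slow clearance), three compounds built on a shared core have been run so far. Compound 1 `CCn1c([C@@H](C)NS(=O)(=O)c2ccc(Cl)cc2)nc2ccc(OC)cc21` reaches the limit of this assay at > 100 mL.min-1.g-1, so no number is known for it. Compound 2 `CCn1c(C(C)NS(=O)(=O)c2ccc(Cl)cc2)nc2ccncc21` gives 93 mL.min-1.g-1. Compound 3 `CCn1c([C@@H](C)NS(=O)(=O)c2ccc(F)cc2)nc2ccc(C(F)(F)F)cc21` gives 26 mL.min-1.g-1, the lower of the two numbers, and its gap to compound 2 is wider than the usual scatter of repeated runs. No two of these three compounds differ in a single place, so no single change can yet be tied to a shift in this assay.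

Compound 4 `CCn1cc(S(=O)(=O)N[C@H](C)c2nc3ccc(C(F)(F)F)cc3n2CC)cn1` has not been measured. It differs from compound 3 in one place: 1-ethyl-1H-pyrazol-4-yl in place of 4-fluorophenyl on a sulfonyl sulfur. For the measured compounds named here, none of the measured compounds tests a change of this kind, so the size of the step is uncertain. The step of a 1.2-fold higher number from compound 3 to compound 4 (0.06 log units; within the scatter) is expected to stay within the scatter, in either direction. Compound 4 is estimated at 30 mL.min-1.g-1, with a range from 12 mL.min-1.g-1 to 75 mL.min-1.g-1.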

Compound 4, intrinsic clearance in microsomes: 95 mL.min-1.g-1
The estimate for compound 4 lay 3.2-fold (0.50 log units) below the measured number; the measured number lies above the stated range.
By their numbers in this assay, from the lowest: compound 3; then compounds 2 and 4 (each within the scatter of the next). At a limit, above all of these: compound 1.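

In this assay, putting 1-ethyl-1H-pyrazol-4-yl in place of 4-fluorophenyl on a sulfonyl sulfur gives a 3.7-fold higher number from compound 3 to compound 4 (0.56 log units; beyond the scatter), the first shift that can be tied to one single change. The step is modest, but it shows that clearance in this series responds to the group at this position. The two groups have the same number of heavy atoms, yet one pair cannot separate the effect of the ring from that of its ethyl chain.

Going by these compounds, whether a pyridine ring or a plain methyl group at this position would give a number closer to compound 3 or to compound 4 remains open. Any rise past compound 4 would be hard to size because the read-out has a ceiling: the limit of > 100 mL.min-1.g-1 in this assay, at which 1 of the 4 values shown sits.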